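Aryl substituent changes on the sulfonyl hydrazide series

The compounds below may be only part of what the source reports. "The series", "measured", "known", "first", "only" and "open" are said of these compounds alone.

Measured compounds:
Compound 1 `CC(=O)Nc1ccc(S(=O)(=O)NNc2ccc(C#N)cc2)cc1` — 1390 nM
Compound 2 `CC(=O)Nc1ccc(S(=O)(=O)NNc2ccc(C(F)(F)F)cc2)cc1` — 181 nM
Compound 3 `CC(=O)Nc1ccc(S(=O)(=O)NNc2ccc(F)cc2)cc1` — 609 nM

All three share one core and differ only in the group on the distal aromatic ring. In an assay on HeLa cells for inhibition of Indoleamine 2,3-dioxygenase 1 (Homo sapiens), read by spectrophotometry, with a stated time of 24 h (on this read-out lower numbers stand for an effect already at smaller amounts and higher numbers for an effect only at larger amounts of compound), compound 3 gives 609 nM, the second highest of the three numbers; compound 1 sits nearer, at a 2.3-fold lower number from compound 1 to compound 3 (0.36 log units; beyond the scatter), and compound 2 lies further off, at a 3.4-fold higher number from compound 2 to compound 3 (0.53 log units; beyond the scatter). The widest step in the set is a 7.7-fold lower number from compound 1 to compound 2 (0.89 log units; beyond the scatter).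

Compound 4 `CC(=O)Nc1ccc(S(=O)(=O)NNc2cccc(Br)c2)cc1` is the next member. Relative to compound 3 the change is 3-bromophenyl in place of 4-fluorophenyl on an amine nitrogen. Going by the values given here, none of the measured steps matches this change: each of them swaps one group for another while keeping the 4-substituted pattern, and no measured pair varies the position on the ring or carries bromine. What the three steps do show is that changes on this ring move this assay only by modest amounts, in either direction.

The expectation for compound 4 is therefore a modest step, direction open, estimated at a 1.4-fold lower number from compound 3 to compound 4 (0.13 log units; within the scatter) relative to compound 3. Compound 4 is expected to give about 450 nM in this assay, within a range of 150 nM to 1400 nM.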

Compound 4, half-maximal effective concentration: 7560 nM
Estimate against measurement, compound 4: 17-fold (1.23 log units) below; the measured number lies above the stated range.
By their numbers in this assay, from the lowest: compound 2; then compound 3; then compound 1; then compound 4.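

In this assay, going by these compounds alone, 3-bromophenyl in place of 4-fluorophenyl on the amine nitrogen gives a 12-fold higher number from compound 3 to compound 4 (1.09 log units; beyond the scatter), the first large step on this ring, whereas the widest step among the earlier compounds was a 7.7-fold lower number from compound 1 to compound 2 (0.89 log units; beyond the scatter), and compound 4 also stands above compound 1 at 1390 nM, the previous highest number in the set. The ring is therefore less forgiving than the three earlier compounds suggested, and the listed counts do not track the step: both groups have the same heavy-atom count, with no hydrogen-bond donors or acceptors and no net charge. No measurement is available that bears on the reason for this rise.

The compounds shown do not separate the change from fluorine to bromine from the change of position on the ring, and these two differences arrive together in compound 4. Also open, going by these compounds, is how this ring responds when an amine or a carboxylic acid replaces the halogen.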